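The source may report more compounds than this note shows. Statements on the series, on what has been measured and on what is new or still open speak of the compounds shown alone.

Working notes on the series.

Within the data shown here, compound 1 `O=C(OC(C(F)(F)F)C(F)(F)F)N1CCN(Cc2ccc(C(F)(F)F)cc2N2C[C@H]3CC[C@@H](C2)O3)CC1` is one of two compounds measured so far in an assay on brain for inhibition of Monoglyceride lipase (Mus musculus), with a stated time of 30 min (on this read-out higher numbers stand for weaker inhibition and lower numbers for stronger inhibition), where compound 1 gives 14 nM. Among the measured compounds shown here, its only measured neighbour is compound 2 `O=C(OC(C(F)(F)F)C(F)(F)F)N1CCN(Cc2ccc(C(F)(F)F)cc2N2CC[C@@H](O)C2)CC1`, which in this assay gives 8 nM; the single recorded step, a 1.8-fold lower number from compound 1 to compound 2 (0.24 log units; within the scatter), stays within the scatter, so the two values give no order between them.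

Compound 3 `CN1CC2CN(c3cc(C(F)(F)F)ccc3CN3CCN(C(=O)OC(C(F)(F)F)C(F)(F)F)CC3)CC2C1` is not yet measured. It differs from compound 1 by a group of 9 heavy atoms (7 carbon, 2 nitrogen; 2 five-membered non-aromatic rings with 1 hetero atom each) in place of a group of 8 heavy atoms (6 carbon, 1 nitrogen, 1 oxygen; one five-membered non-aromatic ring with 1 hetero atom, one six-membered non-aromatic ring with 2 hetero atoms), on an aromatic carbon, on an aromatic carbon of a six-membered aromatic ring of carbon only, ortho to a large group and meta to a trifluoromethyl group. For the measured compounds named here, the one step that bears on this change is the exchange at the same position from compound 1 to compound 2, which was within the scatter. Nothing measured in this series points to a large move in either direction for a further exchange at this position, and the step from compound 1 to compound 3 is therefore expected to be small, a 1.1-fold higher number from compound 1 to compound 3 (0.03 log units; within the scatter). Compound 3 is estimated at 15 nM in this assay, with a range from 5 nM to 45 nM.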

Compound 3, half-maximal inhibitory concentration: 239 nM
The estimate for compound 3 lay 16-fold (1.20 log units) below the measured number; measured number outside the range, above it.
By their numbers in this assay, from the lowest: compounds 2 and 1 (each within the scatter of the next); then compound 3.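

In this assay the place on an aromatic carbon, meta to a trifluoromethyl group, proves not to be indifferent to the group it carries: the group of 9 heavy atoms with 2 five-membered non-aromatic rings gives a 17-fold higher number from compound 1 to compound 3 (1.23 log units; beyond the scatter) and gives a 30-fold higher number from compound 2 to compound 3 (1.48 log units; beyond the scatter) as well. Both steps are large, while the exchange between the two oxygen-containing groups stayed within the scatter, so that earlier pair did not show how much this place can matter; of the three compounds, only compound 3 carries a group of 7 carbon and 2 nitrogen with no oxygen. Nothing on hand bears on why the number rises so far here.

The three compounds cannot separate the exchange of oxygen for a second nitrogen from the change in ring system, as the step to compound 3 alters both at once. From the compounds shown here alone, a morpholine or an unsubstituted pyrrolidine on this aromatic carbon would help to tell these apart, and whether a simple amine behaves like compound 3 or like compound 1 remains open.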